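The compounds below may be only part of what the source reports. "The series", "measured", "known", "first", "only" and "open" are said of these compounds alone.

Of the compounds shown here, two built on one shared core have been measured in an assay on HEK293 cells for displacement of a labelled ligand from tyrosine-protein kinase receptor UFO (Homo sapiens), read by NanoBRET, with a stated time of 2 h; on this read-out lower numbers stand for stronger inhibition and higher numbers for weaker inhibition. Compound 1 `N#Cc1ccccc1-n1cc(-c2n[nH]c3cc(Cl)c(N[C@@H]4CCNC4)cc23)cn1` gives 3540 nM in this assay, and compound 2 `N#Cc1ccc(-n2cc(-c3n[nH]c4cc(Cl)c(N[C@@H]5CCNC5)cc34)cn2)cc1` gives 880 nM. Going by the values given here, the only comparison available, a 4.0-fold lower number from compound 1 to compound 2 (0.60 log units; beyond the scatter), exchanges 2-cyanophenyl for 4-cyanophenyl, and compound 2 holds the lower of the two numbers. Compound 3 `COc1ccc(-n2cc(-c3n[nH]c4cc(Cl)c(N[C@@H]5CCNC5)cc34)cn2)cc1` is the next structure; it differs from compound 2 in one place: methoxy in place of cyano on an aromatic carbon. Among the compounds with values here, no measured step exchanges one group for another at this position, so the single comparison that exists does not bear on this change, and the size and direction of the step stay open. With nothing to anchor it, the step expected for compound 3 is a 1.4-fold higher number from compound 2 to compound 3 (0.13 log units; within the scatter), carrying a wide range either way. Compound 3 is therefore estimated at 1200 nM, expected to fall between 300 nM and 5000 nM.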

Compound 3, half-maximal inhibitory concentration: 374 nM
Estimate against measurement, compound 3: 3.2-fold (0.51 log units) above; the range from low to high includes it.
By their numbers in this assay, from the lowest: compound 3; then compound 2; then compound 1.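

Until now only the place of the nitrile on the phenyl ring had changed. Here the group itself is exchanged at the same place, para to a large group, and in this assay the nitrile proves not to be required, since methoxy gives a 2.4-fold lower number from compound 2 to compound 3 (0.37 log units; beyond the scatter) and stays beyond the scatter. Changing both the group and its place gives a 9.5-fold lower number from compound 1 to compound 3 (0.98 log units; beyond the scatter) as the largest of the three steps, though no measurement here explains why either change lowers the number.

On these data alone, with only a nitrile and a methoxy at this place, it remains open how an amine, a carboxylic acid, a fluorine or a longer chain such as ethoxy would read. As far as these compounds go, it is also open whether methoxy would respond to a move around the ring as the nitrile does.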